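Nitrophenyl in place of trifluoromethylphenyl: an expected step

The source may hold more compounds than are shown below. What is called first, only, known or untested is meant among the compounds shown, and "the series" means these compounds.

Values in a functional assay on MDA-MB-231 cells (Homo sapiens) for antiproliferative activity, read by MTT assay, with a stated time of 72 h (on this read-out higher numbers stand for weaker inhibition and lower numbers for stronger inhibition), are as follows
- compound 1 `CC1=CC[C@H]2[C@H](CC[C@]2(C)O)C(C)(C)[C@@H]1CC[C@H]1[C@]2(C)CC[C@H](OC(=O)NCc3ccccc3)C(C)(C)O[C@H]2CC[C@@]1(C)O` gives 40300 nM
- compound 2 `CC1=CC[C@H]2[C@H](CC[C@]2(C)O)C(C)(C)[C@@H]1CC[C@H]1[C@]2(C)CC[C@H](OC(=O)c3ccc([N+](=O)[O-])cc3)C(C)(C)O[C@H]2CC[C@@]1(C)O` gives 8900 nM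
- compound 3 `CC1=CC[C@H]2[C@H](CC[C@]2(C)O)C(C)(C)[C@@H]1CC[C@H]1[C@]2(C)CC[C@H](OC(=O)c3cccc(C(F)(F)F)c3)C(C)(C)O[C@H]2CC[C@@]1(C)O` gives 36300 nM

Two steps place compound 3 at the high end of the numbers. There is a 1.1-fold lower number from compound 1 to compound 3 (0.05 log units; within the scatter) and there is a 4.1-fold higher number from compound 2 to compound 3 (0.61 log units; beyond the scatter) as well. Compound 4 `CC1=CC[C@H]2[C@H](CC[C@]2(C)O)C(C)(C)[C@@H]1CC[C@H]1[C@]2(C)CC[C@H](OC(=O)c3ccccc3[N+](=O)[O-])C(C)(C)O[C@H]2CC[C@@]1(C)O` differs from it thus: 2-nitrophenyl in place of 3-(trifluoromethyl)phenyl on a carbonyl carbon with 2-nitrophenyl in place of 3-(trifluoromethyl)phenyl on a carbonyl carbon. The nearest guide is compound 2, which carries 4-nitrophenyl instead, and its a 4.5-fold lower number from compound 1 to compound 2 (0.66 log units; beyond the scatter) is only a hint. A small downward move is therefore expected in this assay and the expected step is a 2.1-fold lower number from compound 3 to compound 4 (0.33 log units; beyond the scatter) in this estimate. For compound 4 the estimated value is 17000 nM with an expected range of 7000 nM to 40000 nM for the measurement.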

Compound 4, half-maximal inhibitory concentration: 38700 nM
Compound 4: middle estimate off by 2.3-fold (0.36 log units), on the low side, within the range that was stated.
By their numbers in this assay, from the lowest: compound 2; then compounds 3, 4 and 1 (each within the scatter of the next).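

Exchanging 4-nitrophenyl for 2-nitrophenyl on the carbonyl carbon gives a 4.3-fold higher number from compound 2 to compound 4 (0.64 log units; beyond the scatter) and shows that the lower number of compound 2 does not extend to every nitrophenyl group. The 2-nitrophenyl group instead stands level with 3-(trifluoromethyl)phenyl, with a 1.1-fold higher number from compound 3 to compound 4 (0.03 log units; within the scatter) as the step, and with benzylamino, with a 1.0-fold lower number from compound 1 to compound 4 (0.02 log units; within the scatter) as the step. No evidence is available to explain the gap between the two nitrophenyl groups. On these data alone, what remains open is whether 4-nitrophenyl is unique here, and what an amine or a carboxylic acid in place of the nitro group would give.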